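The source may hold more compounds than are shown below. What is called first, only, known or untested is meant among the compounds shown, and "the series" means these compounds.

Measured compounds:
compound 1 `O=C1c2c[n+]([O-])c3ccccc3c2C(=O)c2c1c1ccccc1n2Cc1cn(C[C@@H](O)CO)nn1` — 140 nM
compound 2 `O=C1c2c[n+]([O-])c3ccccc3c2C(=O)c2c1c1ccccc1n2Cc1cn(CC(O)CO)nn1` — 440 nM
compound 3 `O=C1c2c[n+]([O-])c3ccccc3c2C(=O)c2c1c1ccccc1n2CCCCN1CCCCC1` — 190 nM

In a functional assay on A-375 cells (Homo sapiens) for cytotoxicity, read by MTT assay, with a stated time of 72 h (on this read-out higher numbers stand for weaker inhibition and lower numbers for stronger inhibition), compound 3 stands second highest of the three numbers. Its nearest neighbour is compound 1, and the step of a 1.4-fold higher number from compound 1 to compound 3 (0.13 log units; within the scatter) keeps both inside the usual scatter. Against compound 2 the picture differs, as the step of a 2.3-fold lower number from compound 2 to compound 3 (0.36 log units; beyond the scatter) shows. Compound 4 `CN(C)CCCCn1c2c(c3ccccc31)C(=O)c1c[n+]([O-])c3ccccc3c1C2=O` carries the change (dimethylamino in place of piperidin-1-yl on a saturated chain carbon, four bonds along the chain from an aromatic nitrogen). For the measured compounds named here, no measured step swaps one amine for another at this place. Going by the values given here, the two steps that end at compound 3, a 1.4-fold higher number from compound 1 to compound 3 (0.13 log units; within the scatter) and a 2.3-fold lower number from compound 2 to compound 3 (0.36 log units; beyond the scatter), show only that exchanging the whole group on the saturated chain carbon bound to the aromatic nitrogen moved the number little or modestly, so the shared core appears to carry most of the activity. The expectation for compound 4 is therefore a step of a 1.1-fold higher number from compound 3 to compound 4 (0.04 log units; within the scatter) that does not clear the scatter. Compound 4 is estimated at 210 nM, within 90 nM to 480 nM.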

Compound 4, half-maximal inhibitory concentration: 470 nM
Beside the measured number, compound 4's estimate is 2.2-fold (0.35 log units) below it; the measured number falls inside the stated range.
By their numbers in this assay, from the lowest: compounds 1 and 3 (each within the scatter of the next); then compounds 2 and 4 (each within the scatter of the next).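

In this assay, for the compounds shown here, the amine at the end of the chain turns out to matter: dimethylamino in place of piperidin-1-yl gives a 2.5-fold higher number from compound 3 to compound 4 (0.39 log units; beyond the scatter) and so, at this place on a saturated chain carbon, the two amines are not interchangeable, which no earlier pair could show. Against the triazole-bearing compounds the new amine gives a 1.1-fold higher number from compound 2 to compound 4 (0.03 log units; within the scatter) and a 3.4-fold higher number from compound 1 to compound 4 (0.53 log units; beyond the scatter), so the earlier small step from compound 1 to compound 3 holds for piperidin-1-yl and does not carry over to dimethylamino. Nothing at hand bears on why this exchange moved the number.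

One pair of amines cannot separate the loss of the ring from the loss of heavy atoms, a question that pyrrolidin-1-yl, morpholin-4-yl or diethylamino at this place would address. On these data alone, how a shorter or longer chain carrying either amine would read also remains open.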